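Amide aryl variation on a shared thioacetamide core

A few compounds are considered here, and "the series" means these few. Any claim that something is new, unique, unknown or untested is made for them only; others in the source may bear on it.

Measured compounds in a functional assay on PC-3 cells (Homo sapiens) for inhibition, read by MTT assay, with a stated time of 72 h; on this read-out lower numbers stand for stronger inhibition and higher numbers for weaker inhibition:
compound 1 `O=C(CSc1nc(Nc2ccccc2)c2ccccc2n1)Nc1ccccc1F` gives 12400 nM
compound 2 `O=C(CSc1nc(Nc2ccccc2)c2ccccc2n1)Nc1cccc(Br)c1` gives 11400 nM
compound 3 `O=C(CSc1nc(Nc2ccccc2)c2ccccc2n1)Nc1ccc([N+](=O)[O-])cc1` gives 25000 nM

Compound 3 stands apart from compound 2 by a 2.2-fold higher number from compound 2 to compound 3 (0.34 log units; beyond the scatter) and from compound 1 only by a 2.0-fold higher number from compound 1 to compound 3 (0.30 log units; within the scatter), so its number is the one farthest from the other two, though against compound 1 the gap is within the scatter. Compound 4 `CCc1ccc(NC(=O)CSc2nc(Nc3ccccc3)c3ccccc3n2)cc1` is not yet measured. The change from compound 3 to compound 4 is ethyl in place of nitro on an aromatic carbon, placed para to a large group on the amide aryl ring. The two steps that bear on it are those leading into compound 3: a 2.0-fold higher number from compound 1 to compound 3 (0.30 log units; within the scatter) and a 2.2-fold higher number from compound 2 to compound 3 (0.34 log units; beyond the scatter), both running toward a higher number when 4-nitrophenyl entered. Removing nitro in favour of ethyl is therefore expected to return the number toward the band of compounds 1 and 2, a modest move at most. This amounts to an expected 2.1-fold lower number from compound 3 to compound 4 (0.32 log units; beyond the scatter) in this assay. Compound 4 is estimated at 12000 nM, with a range from 5000 nM to 30000 nM.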

Compound 4, half-maximal inhibitory concentration: 17900 nM
Beside the measured number, compound 4's estimate is 1.5-fold (0.17 log units) below it; measured number inside the range.
By their numbers in this assay, from the lowest: compounds 2, 1, 4 and 3 (each within the scatter of the next, the first and the last beyond it).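

In this assay, ethyl in place of nitro on an aromatic carbon, para to a large group, gives a 1.4-fold lower number from compound 3 to compound 4 (0.15 log units; within the scatter), so this exchange does not separate the two compounds at this position. Within the data shown here, compound 4 is likewise not separated from the other two amide aryl compounds, with a 1.6-fold higher number from compound 2 to compound 4 (0.20 log units; within the scatter) and a 1.4-fold higher number from compound 1 to compound 4 (0.16 log units; within the scatter), which leaves a 2.2-fold higher number from compound 2 to compound 3 (0.34 log units; beyond the scatter) as the only step in the set beyond the scatter. Nothing measured alongside these numbers accounts for them.

On these data alone, whether any group at this position can move the number well beyond the scatter remains open. An amine, a carboxylic acid or a longer chain such as butyl in place of ethyl would test this, with the shared core kept unchanged.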